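Series notes: chloro for fluoro on the sulfonyl aryl

The source may hold more compounds than are shown below. What is called first, only, known or untested is meant among the compounds shown, and "the series" means these compounds.

Measured so far:
Compound 1 `O=C1O[C@H]([C@@H](O)Cn2cc(-c3cccc(O)c3)nn2)C(OCc2ccccc2)=C1OCc1ccccc1` gives 42900 nM in a functional assay on HCT-116 cells (Homo sapiens) for antiproliferative activity, read by MTT assay, with a stated time of 72 h; a lower number here means a stronger inhibitor, a higher number a weaker inhibitor.
Compound 2 `O=C1O[C@H]([C@@H](O)Cn2cc(CNS(=O)(=O)c3ccc(F)cc3)nn2)C(OCc2ccccc2)=C1OCc1ccccc1` gives 22900 nM in this assay.

Compound 2 holds the lower of the two numbers shown, but its only neighbour is compound 1, and the step of a 1.9-fold lower number from compound 1 to compound 2 (0.27 log units; within the scatter), so no order between the two is claimed.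

Compound 3 `O=C1O[C@H]([C@@H](O)Cn2cc(CNS(=O)(=O)c3ccc(Cl)cc3)nn2)C(OCc2ccccc2)=C1OCc1ccccc1` differs from compound 2 by chloro in place of fluoro on an aromatic carbon. Going by the values given here, none of the measured pairs changes this halogen; the single step recorded, a 1.9-fold lower number from compound 1 to compound 2 (0.27 log units; within the scatter), concerns the whole group on the triazole and stays within the scatter, so it offers no direction for the halogen swap. With nothing in the data pointing either way, the expectation for compound 3 in this assay is a number close to that of compound 2, with no step beyond the scatter.

Compound 3 is estimated at 20000 nM, with a range from 8000 nM to 55000 nM.
This estimate for compound 3 is expected to amount to a 1.1-fold lower number from compound 2 to compound 3 (0.06 log units; within the scatter).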

Compound 3, half-maximal inhibitory concentration: 8380 nM
Compound 3: middle estimate off by 2.4-fold (0.38 log units), on the high side, and the stated range covers the measured number.
By their numbers in this assay, from the lowest: compound 3; then compounds 2 and 1 (each within the scatter of the next).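

In this assay, going by these compounds alone, the halogen at this place on the ring, para to a large group, is not silent: going from 4-fluorophenyl to 4-chlorophenyl gives a 2.7-fold lower number from compound 2 to compound 3 (0.44 log units; beyond the scatter) and is the first single-atom change with a step beyond the scatter. The larger group exchange now also reads clearly, with (((4-chlorophenyl)sulfonyl)amino)methyl in place of 3-hydroxyphenyl giving a 5.1-fold lower number from compound 1 to compound 3 (0.71 log units; beyond the scatter) where the 4-fluorophenyl counterpart stayed within the scatter. Nothing available explains the origin of the halogen step.

On these data alone, whether the trend extends to bromo, methyl, trifluoromethyl or methoxy at this place, or to a plain unsubstituted phenyl, remains open. Also open, as far as these compounds go, is whether chloro for fluoro gives a similar step when the benzyl ethers on the core are replaced, for instance by free hydroxyl groups.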